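Swapping Halogens on the Aryl Piperazine: A Small Expected Shift

The source may hold more compounds than are shown below. What is called first, only, known or untested is meant among the compounds shown, and "the series" means these compounds.

Three compounds share one core and differ only in the aromatic group attached to the ring nitrogen. Compound 1 `Nc1scc(CN2CCN(c3ccc([N+](=O)[O-])cc3)CC2)c1C(=O)c1ccc(Cl)cc1` carries a 4-nitrophenyl group; in a functional assay on CHO cells with adenosine receptor A1 (Homo sapiens) as the target, read by cAMP accumulation and immunoassay, with a stated time of 6 min, tested at 1 uM (on this read-out higher numbers stand for a weaker effect at the one concentration tested and lower numbers for a stronger effect), compound 1 gives -8.3%. Compound 2 `Nc1scc(CN2CCN(c3cccc(F)c3)CC2)c1C(=O)c1ccc(Cl)cc1`, with 3-fluorophenyl, gives -86% in this assay, and compound 3 `Nc1scc(CN2CCN(c3c(F)cccc3F)CC2)c1C(=O)c1ccc(Cl)cc1`, with 2,6-difluorophenyl, gives -65%. Compound 3 therefore stands second of the three, with compound 2 closest and compound 1 furthest away. The two steps leading away from the nitro compound were large: a number 77.7 percentage points lower from compound 1 to compound 2 (beyond the scatter) and a number 56.7 percentage points lower from compound 1 to compound 3 (beyond the scatter). Between the two fluorinated compounds the step was smaller: a number 21 percentage points higher from compound 2 to compound 3 (beyond the scatter).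

Compound 4 `Nc1scc(CN2CCN(c3ccc(Cl)c(Cl)c3)CC2)c1C(=O)c1ccc(Cl)cc1` is not yet measured. The change is 3,4-dichlorophenyl in place of 2,6-difluorophenyl on an amine nitrogen in a ring. Within the data shown here, the only step between two halogenated aryl groups, from compound 2 to compound 3, was modest, so a step of similar or smaller size is expected here, leaning toward a lower number as in compound 2, with a number 7 percentage points lower from compound 3 to compound 4 (within the scatter). Compound 4 is thus estimated at -72% in this assay, in a range from -95% to -35%.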

Compound 4, a percentage reported as activity, at one concentration (the size of the read-out at that concentration, not a potency): -60%
Compound 4: the middle estimate sits 12 percentage points below what was measured; the range from low to high includes it.
By their numbers in this assay, from the lowest: compound 2; then compounds 3 and 4 (each within the scatter of the next); then compound 1.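

Putting 3,4-dichlorophenyl in place of 2,6-difluorophenyl on the amine nitrogen in the ring gives, in this assay, a number 5 percentage points higher from compound 3 to compound 4 (within the scatter), so two quite different dihalogenated phenyl groups cannot be told apart at this position. The other comparisons, a number 26 percentage points higher from compound 2 to compound 4 (beyond the scatter) and a number 51.7 percentage points lower from compound 1 to compound 4 (beyond the scatter), place this new group with 2,6-difluorophenyl: apart from 3-fluorophenyl on one side and far from 4-nitrophenyl on the other, so all three halogenated phenyl groups give lower numbers than the nitro compound. Nothing available explains these differences.

From the compounds shown here alone, it remains open whether a halogen is needed here at all, since a plain phenyl group or a methoxyphenyl group would test that. A single chlorine on the phenyl ring would show whether the one-halogen or the two-halogen pattern matters more.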